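A Long Chain on the Isopropyl Carbon

The source may report more compounds than this note shows. Statements on the series, on what has been measured and on what is new or still open speak of the compounds shown alone.

Compound 1 `CCCNc1ccc(NC(=O)c2cc(Cl)ccc2O)c(Cl)c1` gives 22500 nM
Compound 2 `CC(C)Nc1ccc(NC(=O)c2cc(Cl)ccc2O)c(Cl)c1` gives 11000 nM

Compound 2 holds the lower of the two numbers in an ADME assay on A549 cells (Homo sapiens) for cytotoxicity, read by resazurin assay, with a stated time of 48 h (on this read-out lower numbers stand for higher toxicity in this test and higher numbers for lower toxicity in this test), so far. Compound 3 `CCCCCCCCC(C)Nc1ccc(NC(=O)c2cc(Cl)ccc2O)c(Cl)c1` differs from compound 2 by heptyl in place of hydrogen on a saturated chain carbon, two bonds along the chain from a nitrogen on an aromatic ring with heptyl in place of hydrogen on a saturated chain carbon, two bonds along the chain from a nitrogen on an aromatic ring. Among the compounds with values here, only one measured step bears on this change, the modest 2.0-fold lower number from compound 1 to compound 2 (0.31 log units; beyond the scatter) on the same nitrogen, and it offers thin guidance. A somewhat larger move toward a lower number is expected, namely a 2.4-fold lower number from compound 2 to compound 3 (0.39 log units; beyond the scatter) as an estimate. For compound 3 the estimate is 4500 nM with 1200 nM to 17000 nM as its expected range.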

Compound 3, half-maximal cytotoxic concentration: 21900 nM
Estimate against measurement, compound 3: 4.9-fold (0.69 log units) below, outside the stated range (above it).
By their numbers in this assay, from the lowest: compounds 2, 3 and 1 (each within the scatter of the next, the first and the last beyond it).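

In this assay heptyl in place of hydrogen on a saturated chain carbon, two bonds along the chain from a nitrogen on an aromatic ring, gives a 2.0-fold higher number from compound 2 to compound 3 (0.30 log units; within the scatter) and so shows that this carbon carries the added heptyl without a step beyond the scatter. The earlier pair had shown only a change of propyl to isopropyl on that nitrogen. Nothing available accounts for this result.

As far as these compounds go, whether a shorter chain such as ethyl on this carbon would also remain within the scatter of compound 2 stays open. So does the effect of an amine or a carboxylic acid at the end of the heptyl chain.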